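The compounds below may be only part of what the source reports. "The series", "measured", "known", "first", "only" and "open" are said of these compounds alone.

Compound 1 `O=C(Nc1cccc(C(F)(F)F)c1)C1CCN(C/C=C/c2ccccc2)CC1` gives 15600 nM
Compound 2 `O=C(Nc1cccc(F)c1)C1CCN(C/C=C/c2ccccc2)CC1` gives 43300 nM

Both values come from a functional assay on A549 cells (Homo sapiens) for inhibition, read by MTT assay, with a stated time of 72 h; on this read-out lower numbers stand for stronger inhibition and higher numbers for weaker inhibition. Of the two numbers, the higher belongs to compound 2 at 43300 nM and so marks the weaker inhibition. Compound 3 `O=C(Nc1cccc(Cl)c1)C1CCN(C/C=C/c2ccccc2)CC1` is the next to be measured, and its change from compound 2 is chloro in place of fluoro on an aromatic carbon with chloro in place of fluoro on an aromatic carbon, meta to a large group. For the measured compounds named here, one measured step bears on this place: fluoro in place of trifluoromethyl gave a 2.8-fold higher number from compound 1 to compound 2 (0.44 log units; beyond the scatter) as a modest change beyond the scatter. Going by the values given here, no chloro compound has been measured, so the expectation is only that compound 3 falls between the two measured compounds. A smaller step towards stronger inhibition is expected, estimated as a 1.7-fold lower number from compound 2 to compound 3 (0.22 log units; within the scatter) in size. In this assay compound 3 is expected at 26000 nM (estimated range 13000 nM to 50000 nM).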

Compound 3, half-maximal inhibitory concentration: 19100 nM
Estimate against measurement, compound 3: 1.4-fold (0.13 log units) above, within the range that was stated.
By their numbers in this assay, from the lowest: compounds 1 and 3 (each within the scatter of the next); then compound 2.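

Exchanging fluoro for chloro on this aromatic carbon gives a 2.3-fold lower number from compound 2 to compound 3 (0.36 log units; beyond the scatter) in this assay, the first step shown between two halogens, and it shows that the read-out responds to this exchange at this position. Chloro and trifluoromethyl cannot be told apart here, with a 1.2-fold higher number from compound 1 to compound 3 (0.09 log units; within the scatter) as the step between them, so among these three groups fluoro alone stands apart from the other two. Nothing given here accounts for this difference between the groups.

The compounds shown leave open whether other groups on this aromatic carbon, such as a methoxy group, a nitrile or an amine, would fall with fluoro or with chloro and trifluoromethyl. They also leave open whether chloro would give a similar result on another carbon of the same ring.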